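From Imidazolyl to tert-Butyl: an Expected Tolerance Step

The source may report more compounds than this note shows. Statements on the series, on what has been measured and on what is new or still open speak of the compounds shown alone.

The measured compounds:
compound 1 `O=C(/C=C/c1ccc([N+](=O)[O-])o1)c1ccc(-n2ccnc2)cc1`: > 100000 nM
compound 2 `O=C(/C=C/c1ccc([N+](=O)[O-])s1)c1ccc(-n2ccnc2)cc1`: 42700 nM
compound 3 `CCCCc1ccc(C(=O)/C=C/c2ccc([N+](=O)[O-])o2)cc1`: 75700 nM

In an ADME assay on Vero cells (Chlorocebus sabaeus) for cytotoxicity, read by resazurin assay, with a stated time of 72 h (a lower number here means that less compound is tolerated, a higher number that more compound is tolerated), compound 2 gives 42700 nM, the lowest of the two numbers available. Compound 3 gives 75700 nM, and the gap between compound 2 and compound 3 lies within the scatter, so no order can be read from it. Compound 1 reports only a limit in this assay, > 100000 nM; it sits at the limit of > 100000 nM in this assay, at which 1 of the 3 values shown sits.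

Compound 4 `CC(C)(C)c1ccc(C(=O)/C=C/c2ccc([N+](=O)[O-])s2)cc1` differs from compound 2 in one place: tert-butyl in place of 1H-imidazol-1-yl on an aromatic carbon. Within the data shown here, the only measured step that resembles this change is an at least 1.3-fold lower number from compound 1 to compound 3 (0.12 log units; that floor lies within the scatter), which starts from a limit and therefore sets no more than a floor that lies within the scatter. A closely related replacement of the same imidazolyl group by a four-carbon chain thus left this assay essentially unchanged. Compound 4 is therefore expected to show no step beyond the scatter, a 1.1-fold lower number from compound 2 to compound 4 (0.05 log units; within the scatter), and its value is estimated at 38000 nM, within a range from 15000 nM to 95000 nM.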

Compound 4, half-maximal cytotoxic concentration: > 100000 nM
Compound 4 ended at the assay's limit; the forecaster's own chance of this, stated with the estimate: 10%; at least 2.6-fold (0.42 log units) between middle value and limit.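

Replacing 1H-imidazol-1-yl with tert-butyl on this aromatic carbon gives, in this assay, an at least 2.3-fold higher number from compound 2 to compound 4 (0.36 log units; beyond the scatter), so this change at this position now has a readable effect beyond the scatter. The earlier related step, an at least 1.3-fold lower number from compound 1 to compound 3 (0.12 log units; that floor lies within the scatter), gave only a floor within the scatter and could not show this, so the position is not indifferent to the group it carries, at least on the core of compound 2. Compound 4 reports only a limit, > 100000 nM, so the step gives a floor and not a size.

From the compounds shown here alone, how far tolerance extends with these groups stays open: the limit of > 100000 nM in this assay, at which 2 of the 4 values shown sit. Whether an amine, a carboxylic acid or a longer chain at the same position would keep the number at this limit or bring it back towards that of compound 2 also stays open.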